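The source may hold more compounds than are shown below. What is called first, only, known or untested is meant among the compounds shown, and "the series" means these compounds.

In a functional assay on KYSE-410 cells (Homo sapiens) for antiproliferative activity, read by MTT assay, with a stated time of 72 h (a higher number here means a weaker inhibitor, a lower number a stronger inhibitor), compound 1 (`O=C(Nc1cccc(F)c1)c1cc(=O)[nH]c2cc(-c3ccccc3)ccc12`) reports only a limit, > 20000 nM. Within the data shown here, compound 2 (`O=C(Nc1cccc(F)c1)c1cc(=O)[nH]c2cc(-c3cccnc3F)ccc12`) gives 11600 nM, the only true number so far. Compound 3 (`Cc1cc(-c2ccc3c(C(=O)Nc4cccc(F)c4)cc(=O)[nH]c3c2)c(C)cc1F`) differs from it by 4-fluoro-2,5-dimethylphenyl in place of 2-fluoropyridin-3-yl on an aromatic carbon. Among the measured compounds shown here, the sole measured step is an at least 1.7-fold lower number from compound 1 to compound 2 (0.23 log units; that floor lies within the scatter), and it rests on (the limit of > 20000 nM in this assay, at which 1 of the 2 values shown sits), so it gives little guidance on size or direction. No change beyond the scatter is therefore expected, and the estimated step is a 1.3-fold lower number from compound 2 to compound 3 (0.11 log units; within the scatter). For compound 3 the expected value is 9000 nM, with an estimated range of 2500 nM to 25000 nM.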

Compound 3, half-maximal inhibitory concentration: > 20000 nM
Compound 3: only a limit was reported; the forecaster's own chance of this, stated with the estimate: 35%; middle value at least 2.2-fold (0.34 log units) away from the limit.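

In this assay, placing 4-fluoro-2,5-dimethylphenyl on this aromatic carbon gives an at least 1.7-fold higher number from compound 2 to compound 3 (0.23 log units; that floor lies within the scatter), so this carbon-only ring adds no second true number at the position. Compound 3 reports only a limit, > 20000 nM, and the step between compound 1 and compound 3 cannot be read. Readings at this position now rest largely on one limit: the limit of > 20000 nM in this assay, at which 2 of the 3 values shown sit.

As far as these compounds go, whether a pyridine ring bearing an amine or a carboxylic acid in place of the fluorine would give a true number in this assay stays open.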